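The source may hold more compounds than are shown below. What is called first, only, known or untested is meant among the compounds shown, and "the series" means these compounds.

Working notes on the series.

Compound 1 `COc1cc(/C=N/NC(=O)OCc2ccccc2)cc(OC)c1O` is measured in a physicochemical assay on cells (Homo sapiens), with a stated time of 18 h, tested at 1 uM (a higher number here means a weaker effect of the compound at the concentration tested, a lower number a stronger effect), and gives 38%. Compound 3 `COc1cc(/C=N/NC(=O)OCc2ccccc2)ccc1O` is its counterpart with one change, (hydrogen in place of methoxy on an aromatic carbon), and in this assay compound 3 gives 75%. The step of a number 37 percentage points higher from compound 1 to compound 3 (beyond the scatter) is the only measured step of this kind in the set.

Compound 2 `COc1cc(/C=N/N2C(=O)CSC2=S)cc(OC)c1O` carries a different core; how its core differs from that of compound 1 is not broken down here. In this assay compound 2 gives 59%, which stands between the two values of the first pair, beyond the scatter from each.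

Compound 4 `COc1cc(/C=N/N2C(=O)CSC2=S)ccc1O` is not yet measured. It relates to compound 2 by the change (hydrogen in place of methoxy on an aromatic carbon). This is the same kind of change as from compound 1 to compound 3, not the same change: around the place, compound 1 has the hydrogen entering meta to a large group, whereas compound 2 has it meta to a group of 9 heavy atoms, the core itself differing. For the measured compounds named here, with only one measured step to rest on, the step from compound 2 to compound 4 is expected to run in the same direction and of a comparable size, a number 29 percentage points higher from compound 2 to compound 4 (beyond the scatter), because of a number 37 percentage points higher from compound 1 to compound 3 (beyond the scatter) and because compound 2 starts at 59%, which leaves less room toward the top of the scale. Compound 4 is therefore estimated at 88% in this assay, within 70% to 100%.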

Compound 4, a percentage reported as activity, at one concentration (the size of the read-out at that concentration, not a potency): 66%
Estimate against measurement, compound 4: 22 percentage points above; measured number below the stated range.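

In this assay, hydrogen in place of methoxy on the aromatic carbon gives a number 7 percentage points higher from compound 2 to compound 4 (within the scatter), whereas the same kind of change on the core of compound 1 gives a number 37 percentage points higher from compound 1 to compound 3 (beyond the scatter). The change therefore does not carry a step of comparable size from the core of compound 1 to the core of compound 2: the step lies beyond the scatter on the first core and within it on the second, so the first step alone is a poor guide to the second. These two pairs do not establish a rule for other cores, and they do not show which feature of either core accounts for the contrast, since no measurement shown here bears on the reason.

The compounds shown carry only methoxy or hydrogen at this place, so it remains open whether an amine, a chlorine atom or a longer chain such as ethoxy would follow the pattern of the first pair, that of the second, or neither. The hydroxy group is common to all four compounds, which leaves open how either core would respond if a carboxylic acid or an amine stood in its place.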